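Replacing the fluorine on a cyclopropyl amide

This account rests on a few compounds, and the source may have more. Where it says the series, first, only, none or still open, it means among the compounds named here.

Compounds measured so far:
Compound 1 `CC(C)C(=O)N1CC2CC(C1)N2`: 86%
Compound 2 `O=C(C1CCC1)N1CC2CC(C1)N2`: 100%
Compound 3 `O=C([C@H]1C[C@H]1F)N1CC2CC(C1)N2`: 110%

In an assay on SH-EP1 cells for agonist activity at Neuronal acetylcholine receptor; alpha4/beta2 (Homo sapiens), read by FLIPR and calcium flux (on this read-out higher numbers stand for larger maximal responses and lower numbers for smaller maximal responses), compound 3 gives the highest of the three numbers; compound 2 sits within the scatter of it, and only compound 1 lies clearly lower, as the step of a number 24 percentage points higher from compound 1 to compound 3 (beyond the scatter) shows. Compound 4 `C[C@H]1C[C@H]1C(=O)N1CC2CC(C1)N2` is not yet measured. It differs from compound 3 in one place: 2-methylcyclopropyl in place of 2-fluorocyclopropyl on a carbonyl carbon.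

Among the measured compounds shown here, three steps bear on this change, all exchanging the group on the carbonyl carbon. The step of a number 14 percentage points higher from compound 1 to compound 2 (beyond the scatter) and the step of a number 24 percentage points higher from compound 1 to compound 3 (beyond the scatter) were modest, while the step of a number 10 percentage points higher from compound 2 to compound 3 (within the scatter) stayed within the scatter. Small rings on the carbonyl carbon thus gave similar, high responses. For compound 4, a step of a number 10 percentage points lower from compound 3 to compound 4 (within the scatter) is therefore expected, within the scatter. The expected value for compound 4 is 100%, with a range from 85% to 115%.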

Compound 4, largest response reached (Emax), in percent of the reference or control that the assay uses: 87%
For compound 4 the middle estimate is 13 percentage points above the measured one; measured number inside the range.
By their numbers in this assay, from the lowest: compounds 1 and 4 (each within the scatter of the next); then compounds 2 and 3 (each within the scatter of the next).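

On the carbonyl carbon, 2-methylcyclopropyl and 2-fluorocyclopropyl have the same heavy-atom count and ring, yet exchanging them gave a number 23 percentage points lower from compound 3 to compound 4 (beyond the scatter) in this assay, so a small ring alone does not secure the high response. The same holds against cyclobutyl, with a number 13 percentage points lower from compound 2 to compound 4 (beyond the scatter), while the comparison with isopropyl gives a number 1 percentage points higher from compound 1 to compound 4 (within the scatter), which leaves these two groups inseparable. Nothing measured here explains the difference between the fluorine and the methyl. Open, as far as these compounds go, is whether a plain cyclopropyl or a 2-chlorocyclopropyl group would match compound 3 or compound 4.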